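Carboxy swap at the cytotoxicity limit

The source may hold more compounds than are shown below. What is called first, only, known or untested is meant among the compounds shown, and "the series" means these compounds.

compound 1 `Cc1cc(NC(=O)Nc2ccc(C(C)(C)C)cc2)c2ccccc2n1`: > 25000 nM (a limit)
compound 2 `CC(=O)c1ccc(NC(=O)Nc2cc(C)nc3ccccc23)cc1`: > 25000 nM (a limit)
compound 3 `Cc1cc(NC(=O)Nc2ccc(C(F)(F)F)cc2)c2ccccc2n1`: 25000 nM (a number)

These three compounds share a core and differ in one group. They were tested in an ADME assay on HEK293 cells (Homo sapiens) for cytotoxicity, with a stated time of 72 h; a lower number here means that less compound is needed, a higher number that more compound is needed for the effect. Going by the values given here, compound 3 gives 25000 nM, the only actual number of the three. The results of compound 1 and compound 2 are limits of the assay. Two of the three results sit at the same mark, (the limit of > 25000 nM in this assay, at which 2 of the 3 values shown sit).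

Compound 4 `Cc1cc(NC(=O)Nc2ccc(C(=O)O)cc2)c2ccccc2n1` has not yet been measured. The change is carboxy in place of trifluoromethyl on an aromatic carbon, para to a large group.

Three measured steps exchange the group at this place: a step that the two limits leave unreadable from compound 1 to compound 2, a number no higher from compound 1 to compound 3 (the limit leaves the size open) and a number no higher from compound 2 to compound 3 (the limit leaves the size open). None of them has a readable size, so they offer no measured guide to a large move. Among the compounds with values here, still, tert-butyl, acetyl and trifluoromethyl all leave the result in the same region, so no step beyond the usual scatter is expected, because compound 3 gives 25000 nM and no compound here falls away from that mark.

The expected change is no change at the digits printed from compound 3 to compound 4 (within the scatter), and it may well be reported only as a limit.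

For compound 4 the estimated value is 25000 nM, with an expected range from 12500 nM to 50000 nM.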

Compound 4, half-maximal effective concentration: > 25000 nM
Compound 4 gave a limit, no number (the forecaster's own chance of this, stated with the estimate: 75%); the middle value sits exactly at the limit.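

Compound 4 adds a different kind of group to the series: carboxy, with 1 hydrogen-bond donor and 1 hydrogen-bond acceptor, replaces trifluoromethyl, with 0 of each, on the aromatic carbon para to a large group. Even so, the result in this assay remains at the same mark, now joined by a third compound: the limit of > 25000 nM in this assay, at which 3 of the 4 values shown sit. Swapping trifluoromethyl for carboxy gives a number no lower from compound 3 to compound 4 (the limit leaves the size open), so this change brought no drop in the number, although none of the new steps can be read for size.

The limit hides how far the values of compound 1, compound 2 and compound 4 lie past the mark, so these compounds cannot be ranked against one another. Going by these compounds alone, it also remains open whether an amine or a longer chain at this place would give a number clearly lower than the one for compound 3.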